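Indolylthio pyrimidine ureas: urea aryl swap, compound 1 to 4

A few compounds are considered here, and "the series" means these few. Any claim that something is new, unique, unknown or untested is made for them only; others in the source may bear on it.

Measured compounds in a functional assay on HepG2 cells (Homo sapiens) for inhibition, with a stated time of 72 h; on this read-out higher numbers stand for weaker inhibition and lower numbers for stronger inhibition:
compound 1 `COc1ccc(NC(=O)Nc2nc(Sc3c[nH]c4ccccc34)cc(N3CCN(Cc4ccccc4)CC3)n2)cc1` gives 21400 nM
compound 2 `O=C(Nc1ccc(Cl)cc1)Nc1nc(Sc2c[nH]c3ccccc23)cc(N2CCCC2)n1` gives 7870 nM
compound 3 `O=C(Nc1ccccc1)Nc1nc(NC2CC2)cc(Sc2c[nH]c3ccccc23)n1` gives 14300 nM

Compound 1 carries the highest number of the three. Compound 3 sits close to it, within the usual scatter, so no order between compound 1 and compound 3 can be read. Compound 2 lies clearly lower, beyond the scatter, and is the only one of the three that separates itself from compound 1 on this read-out.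

Compound 4 `Cc1cc(Cl)ccc1NC(=O)Nc1nc(Sc2c[nH]c3ccccc23)cc(N2CCN(Cc3ccccc3)CC2)n1` is the unmeasured member. It keeps the shared core of compound 1 and changes only the aryl group on the urea: 4-chloro-2-methylphenyl in place of 4-methoxyphenyl on an amide-type nitrogen

For the measured compounds named here, no pair among the measured compounds differs in this one place alone, so the size of the step cannot be taken from a measured step. Compound 2 offers the only hint that a different urea aryl can go with a lower number, but compound 2 also differs from compound 1 elsewhere, so that hint is weak. The expectation for this assay is a modest move toward a lower number, near the edge of the scatter, and a result within the scatter of compound 1 would not surprise.

Compound 4 is estimated at 12000 nM, with a range from 4000 nM to 36000 nM. The expected step of a 1.8-fold lower number from compound 1 to compound 4 (0.25 log units; within the scatter) is therefore small and downward.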

Compound 4, half-maximal inhibitory concentration: 11700 nM
Compound 4: the middle estimate sits 1.0-fold (0.01 log units) above what was measured; the range from low to high includes it.
By their numbers in this assay, from the lowest: compounds 2, 4, 3 and 1 (each within the scatter of the next, the first and the last beyond it).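

In this assay, for the compounds shown here, the only step read so far at this position, on the amide-type nitrogen, is a 1.8-fold lower number from compound 1 to compound 4 (0.26 log units; within the scatter), with the rest of the structure held constant. The earlier compounds shown here each differed in more than one place and could not isolate this change; here, 4-chloro-2-methylphenyl in place of 4-methoxyphenyl gives a difference that this read-out does not separate from scatter, even though the oxygen-bearing aryl group and its hydrogen-bond acceptor give way to a chlorine-bearing aryl group with no acceptor. No measured property bears on this result, so the step carries no explanation.

The step replaces the methoxy group and brings in chlorine and methyl together, so the share of each remains unresolved, and whether the same aryl swap gives a similar step on a different shared core is also unresolved. Also open, as far as these compounds go, is whether a urea aryl group carrying an amine or a carboxylic acid, or a longer alkyl chain in place of the aryl group, would give a step beyond the scatter.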